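A few compounds are considered here, and "the series" means these few. Any claim that something is new, unique, unknown or untested is made for them only; others in the source may bear on it.

Going by the values given here, compound 2 `CN(C)CCNc1nc(-c2ccc(NC(=O)Nc3ccc(Cl)cc3Cl)cc2)nc2ccsc12` stands at the top of the two numbers known so far: in a functional assay on HT-29 cells (Homo sapiens) for cytotoxicity, read by MTT assay, with a stated time of 72 h (a higher number here means a weaker inhibitor, a lower number a stronger inhibitor), compound 2 gives 1320 nM, while compound 1 `CN(C)CCNc1nc(-c2ccc(NC(=O)Nc3ccccc3)cc2)nc2ccsc12` gives 620 nM. Among the compounds with values here, the single measured step runs between them, a 2.1-fold higher number from compound 1 to compound 2 (0.33 log units; beyond the scatter), so exchanging phenyl for 2,4-dichlorophenyl on the urea nitrogen pushed the number up modestly but clearly.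

Compound 3 `Cc1ccc(NC(=O)Nc2ccc(-c3nc(NCCN(C)C)c4sccc4n3)cc2)cc1` is the next point on that same nitrogen. It differs from compound 2 by 4-methylphenyl in place of 2,4-dichlorophenyl on an amide-type nitrogen. Within the data shown here, the step from compound 1 to compound 2 is the only one that bears on this change, and it bears only in part: compound 3 loses both chlorines, which on that evidence should carry the number back toward where compound 1 sits, but it also gains a methyl, for which no measured step exists. The expectation is therefore a move in this assay of about a 1.9-fold lower number from compound 2 to compound 3 (0.28 log units; within the scatter), a modest fall rather than a large one. Compound 3 is estimated at 700 nM, with a plausible range from 300 nM to 1600 nM.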

Compound 3, half-maximal inhibitory concentration: 2150 nM
Estimate against measurement, compound 3: 3.1-fold (0.49 log units) below, outside the stated range (above it).
By their numbers in this assay, from the lowest: compound 1; then compounds 2 and 3 (each within the scatter of the next).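

Compound 3 shows that the higher number of compound 2 does not depend on chlorine: in this assay, a methyl in place of hydrogen on an aromatic carbon is enough to give a clear move (a 3.5-fold higher number from compound 1 to compound 3 (0.54 log units; beyond the scatter)). The exchange of 2,4-dichlorophenyl for 4-methylphenyl on the urea nitrogen, by contrast, gives a difference that stays within the scatter (a 1.6-fold higher number from compound 2 to compound 3 (0.21 log units; within the scatter)), so these two groups cannot be told apart here, and both stand apart from the plain phenyl of compound 1, which has the lowest number of the three. No evidence at hand explains why either substituted ring differs from plain phenyl.

The compounds shown leave open whether a single chlorine, a methoxy group or a carboxylic acid on this phenyl ring would group with compound 2 and compound 3 or stay with compound 1. They also leave open whether the same ordering would hold if the chain on the shared core carried a morpholine in place of its dimethylamine.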